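Compound 4: Methoxy in Place of Fluoro

The compounds below may be only part of what the source reports. "The series", "measured", "known", "first", "only" and "open" are said of these compounds alone.

Compound 1 `CC1(C)[C@H]2CC[C@]1(C)N(Cc1cn(-c3ccc(F)cc3)nn1)C(=O)C2` stands highest of the three measured compounds in a functional assay on OVCAR-3 cells (Homo sapiens) for inhibition, read by MTT assay, with a stated time of 24 h (on this read-out higher numbers stand for weaker inhibition and lower numbers for stronger inhibition), where compound 1 gives 200 nM. Compound 3 `CC1(C)[C@H]2CC[C@]1(C)N(Cc1cn(-c3ccc(Cl)cc3)nn1)C(=O)C2` gives 160 nM in this assay, and compound 2 `CC1(C)[C@H]2CC[C@]1(C)N(Cc1cn(-c3ccccc3Cl)nn1)C(=O)C2` gives 40 nM. The step of a 1.3-fold lower number from compound 1 to compound 3 (0.10 log units; within the scatter) lies within the scatter, whereas a 5.0-fold lower number from compound 1 to compound 2 (0.70 log units; beyond the scatter) and a 4.0-fold higher number from compound 2 to compound 3 (0.60 log units; beyond the scatter) go beyond it. Compound 4 `COc1ccc(-n2cc(CN3C(=O)C[C@@H]4CC[C@@]3(C)C4(C)C)nn2)cc1` differs from compound 1 by methoxy in place of fluoro on an aromatic carbon. Among the measured compounds shown here, only the step of a 1.3-fold lower number from compound 1 to compound 3 (0.10 log units; within the scatter) bears on this change, since it too alters the group on an aromatic carbon of compound 1, and it was small. For the measured compounds named here, no measured compound carries a methoxy, so the expectation rests on that single step. Compound 4 is therefore expected to show a 1.1-fold lower number from compound 1 to compound 4 (0.05 log units; within the scatter) in this assay, a step not beyond the scatter. The estimated value for compound 4 is 180 nM, with a range from 70 nM to 450 nM.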

Compound 4, half-maximal inhibitory concentration: 250 nM
Beside the measured number, compound 4's estimate is 1.4-fold (0.14 log units) below it; the range from low to high includes it.
By their numbers in this assay, from the lowest: compound 2; then compounds 3, 1 and 4 (each within the scatter of the next).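

In this assay, methoxy joins fluoro and chloro on this aromatic carbon, para to a large group, without a step beyond the scatter: a 1.3-fold higher number from compound 1 to compound 4 (0.10 log units; within the scatter) and a 1.6-fold higher number from compound 3 to compound 4 (0.19 log units; within the scatter). The change to 4-methoxyphenyl leaves the gap to the 2-chlorophenyl compound in place, with a 6.3-fold higher number from compound 2 to compound 4 (0.80 log units; beyond the scatter) beyond the scatter. No evidence on the cause of these results is available. From the compounds shown here alone, whether an amine or a carboxylic acid on this carbon would also stay within the scatter remains open. So does whether methoxy would match chloro on the 2-substituted phenyl.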